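A Third Fluoro on an Active Ring

A few compounds are considered here, and "the series" means these few. Any claim that something is new, unique, unknown or untested is made for them only; others in the source may bear on it.

Three related compounds have been measured in a functional assay on Jurkat cells (Homo sapiens); a lower number here means a stronger inhibitor, a higher number a weaker inhibitor. Compound 1 `CC(C)[C@H](NC(=O)COc1cccc2ccccc12)C(=O)N[C@@H](CC(=O)O)C(=O)COc1ccc(C(F)(F)F)cc1` reaches only a limit of the assay, > 100000 nM. Compound 2 `CC(C)[C@H](NC(=O)COc1cccc2ccccc12)C(=O)N[C@@H](CC(=O)O)C(=O)COc1ccc(F)cc1` also reaches only a limit, > 100000 nM. For the measured compounds named here, compound 3 `CC(C)[C@H](NC(=O)COc1cccc2ccccc12)C(=O)N[C@@H](CC(=O)O)C(=O)COc1c(F)cccc1F`, with its 2,6-difluorophenyl group, gives 2040 nM, the only true number of the three.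

Compound 4 `CC(C)[C@H](NC(=O)COc1cccc2ccccc12)C(=O)N[C@@H](CC(=O)O)C(=O)COc1c(F)cc(F)cc1F` differs from compound 3 by one change: fluoro in place of hydrogen on an aromatic carbon. Fluoro replaces hydrogen on an aromatic carbon, turning 2,6-difluorophenyl into 2,4,6-trifluorophenyl. The new fluoro sits para to a large group and meta to the two fluoro groups already there.

Going by the values given here, two measured steps bear on this, and both are large: an at least 49-fold lower number from compound 1 to compound 3 (1.69 log units; beyond the scatter) and an at least 49-fold lower number from compound 2 to compound 3 (1.69 log units; beyond the scatter). Each swaps the whole ring group, so neither isolates the effect of a single added fluoro. The step that the two limits leave unreadable from compound 1 to compound 2 adds nothing readable. Compound 4 keeps the 2,6-difluorophenyl pattern of compound 3, so it is expected to stay in the same range, with only a slight lean towards a higher number in this assay. The expected change is a 1.5-fold higher number from compound 3 to compound 4 (0.17 log units; within the scatter), which would not stand beyond the scatter. For compound 4 the estimated value is 3000 nM, with an expected range of 500 nM to 20000 nM.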

Compound 4, half-maximal inhibitory concentration: 6840 nM
For compound 4 the middle estimate is 2.3-fold (0.36 log units) below the measured one, within the range that was stated.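

The fluoro at this ring position, para to a large group, is not neutral: in this assay adding it to the active ring gives a 3.4-fold higher number from compound 3 to compound 4 (0.53 log units; beyond the scatter) and so a modest loss of strength. It does not abolish activity, however, since the 2,4,6-trifluorophenyl group still gives an at least 14-fold lower number from compound 2 to compound 4 (1.16 log units; beyond the scatter) and an at least 14-fold lower number from compound 1 to compound 4 (1.16 log units; beyond the scatter) even though compound 2 carries a fluoro at this same position. Going by these compounds, a fluoro here is therefore tolerated when the two other fluoro groups are present, and compound 4 shows that the inactivity of compound 2 cannot be put down to that fluoro alone, although the true size of these last two steps stays unknown, as each starts from a limit of the assay: the limit of > 100000 nM in this assay, at which 2 of the 4 values shown sit.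

The compounds shown leave open whether another group at this position on the 2,6-difluorophenyl ring, such as chloro, methoxy or an amine, would fare better or worse than fluoro. They also leave open what a phenyl ring carrying a single fluoro group alongside the new one would give.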